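The source may hold more compounds than are shown below. What is called first, only, known or untested is meant among the compounds shown, and "the series" means these compounds.

Measured compounds in a functional assay on A549 cells (Homo sapiens) for cytotoxicity, read by MTT assay; a lower number here means a stronger inhibitor, a higher number a weaker inhibitor:
- compound 1 `CCOC(=O)C12C(=O)OCC=C1COC2c1ccccc1` gives a limit only, > 1000000 nM
- compound 2 `CCOC(=O)C12C(=O)OCC=C1COC2c1ccc(F)cc1` gives a limit only, > 1000000 nM
- compound 3 `CCOC(=O)C12C(=O)OCC=C1COC2c1ccc(Br)cc1` gives a limit only, > 1000000 nM

Compound 3 stands at the limit of this assay, and the two other values shown sit at the same limit (the limit of > 1000000 nM in this assay, at which 3 of the 3 values shown sit). Because of that the measured steps give no size: a step that the two limits leave unreadable from compound 1 to compound 3, a step that the two limits leave unreadable from compound 2 to compound 3 and a step that the two limits leave unreadable from compound 1 to compound 2 are all unreadable between limits. No change at the aromatic ring on the saturated ring carbon has yet produced a number in this assay.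

Compound 4 `CCOC(=O)C12C(=O)OCC=C1COC2c1ccccn1` differs from compound 3 by pyridin-2-yl in place of 4-bromophenyl on a saturated ring carbon. Among the compounds with values here, no measured step bears a readable size on this change, and none points in either direction. The expected step is therefore a step that the limit leaves unreadable from compound 3 to compound 4, with a limit again the most likely outcome. For compound 4 in this assay the estimate is 1500000 nM, within a range from 300000 nM to 10000000 nM.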

Compound 4, half-maximal inhibitory concentration: > 1000000 nM
Compound 4 ended at the assay's limit (the forecaster's own chance of this, stated with the estimate: 85%); the middle value does not contradict the limit.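

The steps linking compound 4 with compound 1, compound 2 and compound 3 cannot be read, as all four compounds sit at one limit: the limit of > 1000000 nM in this assay, at which 4 of the 4 values shown sit.

The compounds shown leave open whether any change to the aromatic ring or the shared core gives a readable number in this assay.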